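A few compounds are considered here, and "the series" means these few. Any claim that something is new, unique, unknown or untested is made for them only; others in the source may bear on it.

Measured so far:
- compound 1, `CCCCC(=O)Nc1cc(-c2ccccc2)nc(-c2ccccc2)n1`, in an assay on CHO cells for displacement of a labelled ligand from adenosine receptor A1 (Homo sapiens); a higher number here means a weaker inhibitor, a lower number a stronger inhibitor: 109 nM
- compound 2, `CC(C)CC(=O)Nc1cc(-c2ccccc2)nc(-c2ccccc2)n1`, in this assay: 14.8 nM
- compound 3, `CCCCC(=O)Nc1nc(-c2ccccc2)cc(-c2ccccc2)n1`, in this assay: 27.6 nM

Compound 3 stands second highest of the three numbers in this assay. Its value and that of compound 2 lie within the scatter of one another; against compound 1 it reads lower, beyond the scatter. Compound 1 and compound 3 share the same amide and the same two phenyl substituents and differ only in the arrangement of the shared core, a pair for which no single step is listed.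

Compound 4, `O=C(Nc1nc(-c2ccccc2)cc(-c2ccccc2)n1)C1CCC1`, follows from compound 3 by cyclobutyl in place of butyl on a carbonyl carbon. Among the measured compounds shown here, the one measured step that bears on a change at the chain next to the carbonyl is a 7.4-fold lower number from compound 1 to compound 2 (0.87 log units; beyond the scatter), where branching at the saturated chain carbon bound to the carbonyl carbon gave a modest gain on the other core arrangement. Closing the chain into a ring is a related but not identical change, and it is made here on the core of compound 3, so the transfer is uncertain. A smaller step in the same direction is expected: a 2.0-fold lower number from compound 3 to compound 4 (0.29 log units; within the scatter). For compound 4 the estimate in this assay is 14 nM, with a range from 5 nM to 45 nM.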

Compound 4, inhibition constant: 107 nM
Beside the measured number, compound 4's estimate is 7.6-fold (0.88 log units) below it; the whole stated range lies below it.
By their numbers in this assay, from the lowest: compounds 2 and 3 (each within the scatter of the next); then compounds 4 and 1 (each within the scatter of the next).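

Cyclobutyl in place of butyl on a carbonyl carbon gives a 3.9-fold higher number from compound 3 to compound 4 (0.59 log units; beyond the scatter) in this assay with the heavy-atom count unchanged, so in this pair, the ring, rather than the number of heavy atoms, marks the difference. This step runs opposite to a 7.4-fold lower number from compound 1 to compound 2 (0.87 log units; beyond the scatter) in the same assay, so the two changes at this chain do not share a direction, although they differ in both the group and the arrangement of the core. No available evidence accounts for the higher number of compound 4. Going by these compounds, it remains open whether the result belongs to this ring size or to ring closure generally, which cyclopropyl or cyclohexyl on the same carbonyl carbon could separate. Also open, on these data alone, is how isopropyl-bearing chains behave on the core of compound 3.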